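Cytotoxicity notes: fluoropyridinyl replacing fluorophenyl

The source may report more compounds than this note shows. Statements on the series, on what has been measured and on what is new or still open speak of the compounds shown alone.

Compound 1 `O=C(O)c1cccc(-c2ccc(/C=C3\S/C(=N\c4ccc(F)cc4)N(c4ccc(F)cc4)C3=O)o2)c1` sits at the limit > 200000 nM in an ADME assay on Vero cells (Chlorocebus sabaeus) for cytotoxicity; on this read-out higher numbers stand for lower toxicity in this test and lower numbers for higher toxicity in this test.
Compound 2 `O=C(O)c1cccc(-c2ccc(/C=C3\S/C(=N\c4ccccc4)N(c4ccc(Cl)cc4)C3=O)s2)c1` sits at the limit > 200000 nM in this assay.
Compound 3 `O=C(O)c1cccc(-c2ccc(/C=C3\S/C(=N\c4ccccc4)N(c4ccc(F)cc4)C3=O)o2)c1` sits at the limit > 200000 nM in this assay.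

Compound 3 thus has only a limit, and the two other values are limits as well. For the measured compounds named here, the one single-point step, a step that the two limits leave unreadable from compound 1 to compound 3, is unreadable, because the limit of > 200000 nM in this assay, at which 3 of the 3 values shown sit, holds all three readings. Compound 4 `O=C(O)c1cccc(-c2ccc(/C=C3\S/C(=N\c4ccccc4)N(c4ccc(F)cn4)C3=O)o2)c1` differs by 5-fluoropyridin-2-yl in place of 4-fluorophenyl on an amide-type nitrogen in a ring. Going by the values given here, no measured step bears on this change, so no shift beyond the scatter is expected in this assay; the estimate is that the reading again stops at the limit. Compound 4 is expected at 300000 nM, with a range of 100000 nM to 1000000 nM. The expected step is a step that the limit leaves unreadable from compound 3 to compound 4, within the scatter.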

Compound 4, half-maximal cytotoxic concentration: > 200000 nM
Compound 4 was reported as a limit (the forecaster's own chance of this, stated with the estimate: 85%); the middle value does not contradict the limit.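

No step can be read between compound 3 and compound 4, because both readings stop at the same limit: the limit of > 200000 nM in this assay, at which 4 of the 4 values shown sit.

From the compounds shown here alone, whether 5-fluoropyridin-2-yl in place of 4-fluorophenyl changes the cytotoxic concentration in this assay stays open.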